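The compounds below may be only part of what the source reports. "The series", "measured", "known", "first", "only" and "open" are said of these compounds alone.

Three compounds share one core and differ only in the group carried on one aromatic carbon. Compound 1 `C[C@H](Nc1nc(N)nc(N)c1C#N)c1cc2ccc(F)cn2c(=O)c1-c1ccccc1` carries hydrogen there, and in an ADME assay on microsomes from liver (Homo sapiens), read by LC-MS, using NADPH, with a stated time of 30 min, tested at 1 uM (on this read-out higher numbers stand for a more stable compound and lower numbers for a less stable compound), compound 1 gives 87%. Compound 2 `C[C@H](Nc1nc(N)nc(N)c1C#N)c1c(-c2ccccc2)c(=O)n2cc(F)ccc2c1-c1ccc(C(N)=O)cc1` carries a 4-carbamoylphenyl group, and in this assay compound 2 gives 105%. Compound 3 `COc1ccc(-c2c([C@H](C)Nc3nc(N)nc(N)c3C#N)c(-c3ccccc3)c(=O)n3cc(F)ccc23)cc1` carries a 4-methoxyphenyl group, and in this assay compound 3 gives 89%. Compound 3 thus stands close to compound 1, since the change a number 2 percentage points higher from compound 1 to compound 3 (within the scatter) lies within the scatter, while the change a number 16 percentage points lower from compound 2 to compound 3 (beyond the scatter) sets it clearly apart from compound 2; the change a number 18 percentage points higher from compound 1 to compound 2 (beyond the scatter) is of the same modest size.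

Compound 4 `C[C@H](Nc1nc(N)nc(N)c1C#N)c1c(-c2ccccc2)c(=O)n2cc(F)ccc2c1-c1ccc(F)cc1` differs from compound 3 by one exchange: fluoro in place of methoxy on an aromatic carbon. Among the compounds with values here, no measured pair covers fluoro in this position. What the measured steps show is that swapping small groups para to a large group moved this read-out only modestly, and hydrogen against methoxy not at all beyond the scatter. A step of a number 2 percentage points lower from compound 3 to compound 4 (within the scatter) is therefore expected, that is, none beyond the scatter. For compound 4 the expected value is 87%, with a range from 70% to 102%.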

Compound 4, percent of the compound remaining: 87%
The estimate for compound 4 equals the measured number at the digits printed, within the range that was stated.
By their numbers in this assay, from the lowest: compounds 1, 4 and 3 (each within the scatter of the next); then compound 2.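

In this assay, fluoro in place of methoxy gives a number 2 percentage points lower from compound 3 to compound 4 (within the scatter) and the whole 4-fluorophenyl group in place of hydrogen gives no change at the digits printed from compound 1 to compound 4 (within the scatter); a second small group on this ring thus joins methoxy in leaving the number level with that of the core without the ring. Set against the carbamoyl group, fluoro gives a number 18 percentage points lower from compound 2 to compound 4 (beyond the scatter), so among these four compounds compound 2 alone stands apart, and this now holds against two different small groups as well as against hydrogen. Nothing available here accounts for that difference.

The compounds shown leave open whether the higher number belongs to the carbamoyl group alone or would also come with an amine, a carboxylic acid or a longer chain in the same place on the ring.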